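The compounds below may be only part of what the source reports. "The series", "measured", "known", "first", "only" and "open" are said of these compounds alone.

Measured so far in a functional assay on the whole organism for inhibition, with Mus musculus as the target, in the writhing test, with a stated time of 1 h, at a dose of 60 mg/kg by the oral route; on this read-out lower numbers stand for less inhibition and higher numbers for more inhibition at the one dose given (going by the name of the read-out): compound 1 `CC1C(=O)CC(c2ccc(Cl)cc2)N(C(=O)CN2CCN(C)CC2)C1c1ccc(N(C)C)cc1` gives 28.1%; compound 2 `COc1ccc(C2C(C)C(=O)CC(c3ccc(F)cc3)N2C(=O)CCl)cc1` gives 51.2%; compound 3 `CC1C(=O)CC(c2ccc(Cl)cc2)N(C(=O)CCl)C1c1ccc(N(C)C)cc1` gives 17.8%.

Compound 2 stands highest of the three in this assay, with both gaps beyond the scatter. The difference between the core of compound 2 and the core of compound 3 is not broken down here. One change recurs: 4-methylpiperazin-1-yl in place of chloro on a saturated chain carbon bound to a carbonyl carbon, which gave a number 10.3 percentage points higher from compound 3 to compound 1 (beyond the scatter). Compound 4 `COc1ccc(C2C(C)C(=O)CC(c3ccc(F)cc3)N2C(=O)CN2CCN(C)CC2)cc1` carries the same change against compound 2, (4-methylpiperazin-1-yl in place of chloro on a saturated chain carbon bound to a carbonyl carbon), at the same place.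

For the measured compounds named here, a step of like size is expected here, a number 8.8 percentage points higher from compound 2 to compound 4 (within the scatter), and it rests only on the single precedent a number 10.3 percentage points higher from compound 3 to compound 1 (beyond the scatter) on the other core, so the range is kept wide. Compound 4 is therefore expected to give 60%, between 44% and 76%.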

Compound 4, a percentage reported as inhibition, in the whole organism at one dose (the size of the read-out at that dose, not a potency) in the Mus musculus assay: 55.2%
The estimate for compound 4 lay 4.8 percentage points above the measured number, within the range that was stated.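

In the Mus musculus assay the same change on the core of compound 2 gives a number 4 percentage points higher from compound 2 to compound 4 (within the scatter), and the step does not differ measurably between the two cores: the same change on two cores in the Mus musculus assay, a number 10.3 percentage points higher (beyond the scatter) from compound 3 to compound 1 and a number 4 percentage points higher (within the scatter) from compound 2 to compound 4, 6.3 percentage points apart, within the scatter of two such steps. So the change carries over within the scatter, but two pairs do not establish a constant step, and only the step on the core of compound 1 lies beyond the scatter. In a physicochemical assay for lipophilicity, using the shake flask method (a higher number here means a more lipophilic compound, a lower number a more polar compound), compound 2 gives 1.42 and compound 4 gives 1.53, two values within the scatter of each other.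

The compounds shown leave open whether morpholin-4-yl in place of chloro would follow the same course on both cores. They also leave open what a longer chain carrying 4-methylpiperazin-1-yl would give.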